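The source may report more compounds than this note shows. Statements on the series, on what has been measured and on what is new or still open speak of the compounds shown alone.

Measured so far in a functional assay on MOLT-4 cells (Homo sapiens) for inhibition, read by MTT assay, with a stated time of 72 h; a lower number here means a stronger inhibitor, a higher number a weaker inhibitor:
- compound 1 `COc1cc(NC(C)CCCNC(=O)Nc2ccc(Br)cc2)c2ncccc2c1` gives 25000 nM
- compound 2 `COc1cc(NC(C)CCCNC(=O)NNC(=O)Nc2ccc(C(F)(F)F)cc2)c2ncccc2c1` gives 24000 nM

Compound 2 lies within the scatter of compound 1, so these two values give no order. Compound 3 `COc1cc(NC(C)CCCNC(=O)NNC(=O)Nc2ccc(Br)cc2)c2ncccc2c1`, not yet measured, has bromo in place of trifluoromethyl on an aromatic carbon, para to a large group (bromo in place of trifluoromethyl on an aromatic carbon). Going by the values given here, the 4-bromophenyl also occurs in compound 1 at 25000 nM, but no measured step isolates this change. In this assay a step within the scatter is expected, with no preferred direction. The expected change is a 1.1-fold lower number from compound 2 to compound 3 (0.04 log units; within the scatter). For compound 3 the estimated value is 22000 nM, with an expected range of 10000 nM to 50000 nM.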

Compound 3, half-maximal inhibitory concentration: 209000 nM
Estimate against measurement, compound 3: 9.5-fold (0.98 log units) below, outside the stated range (above it).
By their numbers in this assay, from the lowest: compounds 2 and 1 (each within the scatter of the next); then compound 3.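

In this assay the group on the aromatic carbon is not neutral when the carbamoylamino unit is present: bromo in place of trifluoromethyl gives an 8.7-fold higher number from compound 2 to compound 3 (0.94 log units; beyond the scatter). With 4-bromophenyl common to both compounds, ((4-bromophenyl)carbamoyl)amino in place of 4-bromophenyl on the amide-type nitrogen gives an 8.4-fold higher number from compound 1 to compound 3 (0.92 log units; beyond the scatter), so the extended unit is not interchangeable with the simpler one when bromo is present. No measurement at hand accounts for either step.

Open, as far as these compounds go, is whether chloro or nitrile at this place would track bromo or trifluoromethyl. Also open, from the compounds shown here alone, is whether trifluoromethyl on the chain of compound 1 would show the same step.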